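Swapping fluoro for chloro on a breast-cancer growth assay

The source may report more compounds than this note shows. Statements on the series, on what has been measured and on what is new or still open speak of the compounds shown alone.

Three compounds share a core and were measured in a functional assay on cells (Panel breast (Carcinoma cell lines), Homo sapiens) for inhibition; on this read-out lower numbers stand for stronger inhibition of growth and higher numbers for weaker inhibition of growth. Compound 1 `Oc1cc(-c2cccc(Cl)c2)nc2ncccc12` gives 1170 nM. Among the measured compounds shown here, compound 3 `Cc1ccc2c(O)cc(-c3cccc(Cl)c3)nc2n1` gives 3800 nM, and the one measured step, a 3.2-fold higher number from compound 1 to compound 3 (0.51 log units; beyond the scatter), shows that adding the methyl weakened growth inhibition. Compound 2 `Cc1cnc2[nH]c(-c3cccc(F)c3)cc(=O)c2c1` gives 537 nM, the lowest of the three numbers; compound 1 sits beyond the scatter above it and compound 3 further still.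

Compound 4 `Cc1cnc2[nH]c(-c3cccc(Cl)c3)cc(=O)c2c1` has not been measured. It differs from compound 2 in one place: chloro in place of fluoro on an aromatic carbon. One heavy atom leaves and one enters, with no change in ring count, hydrogen-bond donors, acceptors or charge. For the measured compounds named here, no measured step exchanges fluoro for chloro, so the methyl step between compound 1 and compound 3 says nothing direct about this change. With nothing pointing either way, the expected step of a 1.7-fold higher number from compound 2 to compound 4 (0.22 log units; within the scatter) is small, close to the scatter, perhaps slightly weaker. Compound 4 is therefore estimated at 900 nM, within 300 nM to 3000 nM, in this assay.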

Compound 4, concentration for total growth inhibition: 12900 nM
The estimate for compound 4 lay 14-fold (1.16 log units) below the measured number; measured number above the stated range.
By their numbers in this assay, from the lowest: compound 2; then compound 1; then compound 3; then compound 4.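

This position, on the aromatic ring of carbon only, proves far more sensitive in this assay than a swap of one halogen for another suggested: with ring count, hydrogen-bond donors, acceptors and charge all unchanged, the exchange gives a 24-fold higher number from compound 2 to compound 4 (1.38 log units; beyond the scatter). That single-atom change moves the number further than adding the methyl did, which gave a 3.2-fold higher number from compound 1 to compound 3 (0.51 log units; beyond the scatter). Nothing available here explains why the chloro compound is so much weaker.

The compounds shown leave open whether fluoro would also beat chloro on the core of compound 1, where only chloro appears, and where a plain hydrogen at this position would fall relative to compound 2 and compound 4. They also leave open how a different group in this place, such as a methoxy group or an amine, would behave.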